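The compounds below may be only part of what the source reports. "The series", "measured", "known", "first", "only" and "open" are said of these compounds alone.

Series notes. Within the data shown here, in an assay on isolated protein for inhibition of thymidine kinase, cytosolic (Homo sapiens) (on this read-out higher numbers stand for weaker inhibition and lower numbers for stronger inhibition), compound 1 `Cc1cn([C@H]2C[C@H](CF)[C@@H](COP(=O)(O)O)O2)c(=O)[nH]c1=O` gives 40000 nM, while compound 2 `Cc1cn([C@H]2C[C@H](CO)[C@@H](CO)O2)c(=O)[nH]c1=O` gives 420000 nM, the highest of the two numbers, a gap beyond the scatter; the two differ in more than one place, so no single step is drawn from them. Compound 3 `Cc1cn([C@H]2C[C@H](CO)[C@@H](COP(=O)(O)O)O2)c(=O)[nH]c1=O` carries a group of 4 heavy atoms (3 oxygen, 1 phosphorus; no ring) in place of a hydrogen atom, on an oxygen on a saturated carbon relative to compound 2. Among the measured compounds shown here, no measured step covers this change; on the basis of compound 1 at 40000 nM, a drop beyond the scatter is expected, about an 8.4-fold lower number from compound 2 to compound 3 (0.92 log units; beyond the scatter). Compound 3 is therefore estimated at 50000 nM, with a range from 10000 nM to 200000 nM in this assay.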

Compound 3, inhibition constant: 43500 nM
For compound 3 the middle estimate is 1.1-fold (0.06 log units) above the measured one; measured number inside the range.
By their numbers in this assay, from the lowest: compounds 1 and 3 (each within the scatter of the next); then compound 2.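

In this assay, among these compounds, the group of 4 heavy atoms (3 oxygen, 1 phosphorus) in place of a hydrogen atom, on an oxygen on a saturated carbon, gives a 9.7-fold lower number from compound 2 to compound 3 (0.98 log units; beyond the scatter) as the first single-place reading of this change. With that group present, hydroxy in place of fluoro on a saturated chain carbon bound to a saturated ring carbon gives a 1.1-fold higher number from compound 1 to compound 3 (0.04 log units; within the scatter) and so separates nothing here. From the compounds shown here alone, whether an amine or a carboxylic acid on that oxygen would give a similar step stays open, as does the effect of fluoro without that group. Nothing at hand bears on the origin of either step.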